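Amino Added to the Anilino Ring of a Sulfonyl Quinoxaline

The source may hold more compounds than are shown below. What is called first, only, known or untested is meant among the compounds shown, and "the series" means these compounds.

Measured so far:
Compound 1, `Cc1ccc(S(=O)(=O)c2nc3ccccc3nc2Nc2ccc(N)cc2)cc1`, gives 5000 nM
Compound 2, `O=S(=O)(c1ccc(Br)cc1)c1nc2ccccc2nc1Nc1ccccc1`, gives 1180 nM

Both were tested in a functional assay on PC-3 cells (Homo sapiens) for cytotoxicity, read by MTT assay, with a stated time of 72 h; a higher number here means a weaker inhibitor, a lower number a stronger inhibitor. Of the two numbers, compound 2 holds the lower one, and its gap to compound 1 lies beyond the usual scatter of repeated measurements, so compound 2 counts as the stronger inhibitor of the pair.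

Compound 3, `Nc1ccc(Nc2nc3ccccc3nc2S(=O)(=O)c2ccc(Br)cc2)cc1`, has not yet been measured. It keeps the shared core and the bromophenyl sulfonyl of compound 2 and differs in one place: amino in place of hydrogen on an aromatic carbon, an amino in place of hydrogen on an aromatic carbon.

For the measured compounds named here, no measured pair shows this change on its own, so its effect is unknown. The expected step of a 2.1-fold higher number from compound 2 to compound 3 (0.33 log units; beyond the scatter) is a modest rise, toward a weaker inhibitor, though a step within the scatter is equally possible. Compound 3 is therefore expected to give about 2500 nM, within a range from 800 nM to 8000 nM.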

Compound 3, half-maximal inhibitory concentration: 2330 nM
Compound 3: the middle estimate sits 1.1-fold (0.03 log units) above what was measured; low and high end bracket the measured number.
By their numbers in this assay, from the lowest: compounds 2 and 3 (each within the scatter of the next); then compound 1.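

In this assay, the step for adding the amino group to the anilino ring is a 2.0-fold higher number from compound 2 to compound 3 (0.30 log units; within the scatter), so with the bromophenyl sulfonyl in place, this pair cannot be told apart. With the (4-aminophenyl)amino group kept, the other single change, bromo in place of methyl on the sulfonyl-bound ring, gives a 2.1-fold lower number from compound 1 to compound 3 (0.33 log units; beyond the scatter), a modest step that can be read as real. The data shown offer no measurement that explains either step.

Going by these compounds, whether the amino step would stay this small with a methyl rather than a bromo on the sulfonyl-bound ring remains open. So does the outcome of putting a hydroxyl or a methoxy group at the same place on the anilino ring, or a chloro or a methoxy group in place of the bromo.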